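The compounds below may be only part of what the source reports. "The series", "measured", "known", "first", "only" and "open" are said of these compounds alone.

Measured so far:
Compound 1 `Oc1cccc(-c2nc(N3CCCCC3)c3nc[nH]c3n2)c1` in an assay on cells for displacement of a labelled ligand from adenosine receptor A3 (Homo sapiens), read by scintillation counting and radioligand binding, with a stated time of 180 min, tested at 10 uM (a lower number here means less inhibition, a higher number more inhibition at the concentration tested (going by the name of the read-out)), gives > 80%, a limit of the assay.
Compound 2 `Cn1cnc2c(N3CCCCC3)nc(-c3cccc(O)c3)nc21` in this assay gives 49.1%.
Compound 3 `Clc1cccc(-c2nc(N3CCCCC3)c3nc[nH]c3n2)c1` in this assay gives > 80%, also a limit of the assay.

Two of the three values sit at the limit of > 80% in this assay, at which 2 of the 3 values shown sit. From compound 1 to compound 2 the change is methyl in place of hydrogen on an aromatic nitrogen, and in this assay the step is a number at least 30.9 percentage points lower from compound 1 to compound 2 (beyond the scatter). The cores of compound 1 and compound 3 differ by chloro in place of hydroxy on an aromatic carbon; the step that the two limits leave unreadable from compound 1 to compound 3 cannot be read because both values are limits.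

Compound 4 `Cn1cnc2c(N3CCCCC3)nc(-c3cccc(Cl)c3)nc21` is not yet measured. It differs from compound 3 by methyl in place of hydrogen on an aromatic nitrogen, the same change as from compound 1 to compound 2, at a place described in the same words. In this assay the expected step is a number at least 30 percentage points lower from compound 3 to compound 4 (beyond the scatter), resting on the measured step of a number at least 30.9 percentage points lower from compound 1 to compound 2 (beyond the scatter). Compound 4 is therefore estimated at 50%, with a range from 25% to 78%.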

Compound 4, a percentage reported as inhibition, at one concentration (the size of the read-out at that concentration, not a potency): 6.1%
Beside the measured number, compound 4's estimate is 43.9 percentage points above it; the whole stated range lies above it.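

On the core carrying chloro, methyl in place of hydrogen on an aromatic nitrogen gives a number at least 73.9 percentage points lower from compound 3 to compound 4 (beyond the scatter), so in this assay the change points the same way on both cores shown. Whether its size carries over from one core to the other stays unread: the same change on two cores in this assay, a number at least 30.9 percentage points lower (beyond the scatter) from compound 1 to compound 2 and a number at least 73.9 percentage points lower (beyond the scatter) from compound 3 to compound 4; the limit leaves it open whether they differ

With the methyl present, chloro in place of hydroxy on an aromatic carbon gives a number 43 percentage points lower from compound 2 to compound 4 (beyond the scatter), so the two methylated compounds separate clearly, while the step between the two limits cannot be read.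

Open, going by these compounds, is whether an ethyl group or a longer chain on that aromatic nitrogen follows the methyl. Also open, on these data alone, is how an amine or a carboxylic acid behaves on the aromatic carbon that carries hydroxy or chloro.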